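Swapping the Aryl Group on the Triazole Nitrogen

The source may report more compounds than this note shows. Statements on the series, on what has been measured and on what is new or still open speak of the compounds shown alone.

Swapping the Aromatic Group on an Aromatic Nitrogen

- Compound 1 `Cc1ccc(-n2cc(-c3ccc(/C=C4\C(=O)Nc5ccc(F)cc54)cc3)nn2)cc1`: 34600 nM
- Compound 2 `O=C1Nc2ccc(F)cc2/C1=C/c1ccc(-c2cn(-c3cccc(F)c3)nn2)cc1`: 8190 nM

Going by the values given here, in a functional assay on MKN-45 cells (Homo sapiens) for inhibition, read by CCK-8 assay, with a stated time of 24 h (on this read-out higher numbers stand for weaker inhibition and lower numbers for stronger inhibition), compound 2 gives 8190 nM, the lower of the two numbers so far, which makes it the stronger inhibitor of the pair. Compound 3 `O=C1Nc2ccc(F)cc2/C1=C/c1ccc(-c2cn(-c3ccccc3Cl)nn2)cc1` keeps the shared core and alters only the aromatic group on an aromatic nitrogen: 2-chlorophenyl in place of 3-fluorophenyl on an aromatic nitrogen. Among the compounds with values here, one measured step bears on this, a swap at the same place: a 4.2-fold lower number from compound 1 to compound 2 (0.63 log units; beyond the scatter). That step was modest, and it offers a guide to size only. Within the data shown here, no measured compound carries a 2-chlorophenyl group, so the data give no firm direction. A modest change either way remains possible, but no step beyond the scatter is the best single expectation. The expected change is a 1.2-fold higher number from compound 2 to compound 3 (0.09 log units; within the scatter). In this assay the estimate for compound 3 is 10000 nM, expected to lie between 3500 nM and 30000 nM.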

Compound 3, half-maximal inhibitory concentration: 7540 nM
Compound 3: middle estimate off by 1.3-fold (0.12 log units), on the high side; the range from low to high includes it.
By their numbers in this assay, from the lowest: compounds 3 and 2 (each within the scatter of the next); then compound 1.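

In this assay, the step of a 1.1-fold lower number from compound 2 to compound 3 (0.04 log units; within the scatter) lies within the scatter, so 2-chlorophenyl and 3-fluorophenyl on this aromatic nitrogen cannot be told apart, even though their names differ in both the halogen and its ring position. Measured against 4-methylphenyl, the step of a 4.6-fold lower number from compound 1 to compound 3 (0.66 log units; beyond the scatter) lies beyond the scatter and is close in size to the step of a 4.2-fold lower number from compound 1 to compound 2 (0.63 log units; beyond the scatter). Both halogen-bearing phenyl groups therefore give lower numbers than the methyl-bearing one, which now makes two separate swaps at this position pointing the same way. Still open, from the compounds shown here alone, is what an unsubstituted phenyl, a 4-chlorophenyl, or a non-aromatic group such as cyclohexyl or a short chain ending in an amine would do on this nitrogen. No measurement at hand explains why these numbers fall as they do.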